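Benzyl for methylsulfonyl on the ring nitrogen

This account rests on a few compounds, and the source may have more. Where it says the series, first, only, none or still open, it means among the compounds named here.

Compound 2 `CNCc1cc(-c2ccccc2)n(S(C)(=O)=O)c1` stands lowest of the two numbers in hand: in a functional assay on the whole organism (stomach, strain Jcl:Sprague-Dawley) for inhibition, with Rattus norvegicus as the target, with stated times of 3 min and 3 h, at a dose of 10 mg/kg by the intravenous route (a higher number here means more inhibition at the dose given (going by the name of the read-out), a lower number less inhibition), compound 2 gives 27%, whereas compound 1 `CCNCc1cc(-c2ccccc2)n(S(=O)(=O)c2ccc(C)cc2)c1` gives 53%, a gap beyond the scatter, though these two structures differ in more than one place. Compound 3 `CNCc1cc(-c2ccccc2)n(Cc2ccccc2)c1` is as yet untested; set against compound 2 the counted difference is benzyl in place of methylsulfonyl on an aromatic nitrogen. Going by the values given here, no measured pair isolates this change, so the step of a number 11 percentage points higher from compound 2 to compound 3 (beyond the scatter) is expected to be small, upward if anything, and may not clear the scatter. Compound 3 is estimated at 38%, within 15% to 65%.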

Compound 3, a percentage reported as inhibition, in the whole organism at one dose (the size of the read-out at that dose, not a potency): 84%
Compound 3: middle estimate off by 46 percentage points, on the low side; the measured number lies above the stated range.
By their numbers in this assay, from the lowest: compound 2; then compound 1; then compound 3.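

In this assay, going by these compounds alone, benzyl in place of methylsulfonyl on the aromatic nitrogen gives a number 57 percentage points higher from compound 2 to compound 3 (beyond the scatter) on an otherwise unchanged core, the first comparison that differs in one place. The group on this nitrogen therefore moves the inhibition strongly at the dose given, and a sulfonyl group is not required there for inhibition. No measurement at hand bears on why the step is this large.

As far as these compounds go, whether the step belongs to the aromatic ring of benzyl or to the departure of methylsulfonyl stays open. A cyclohexylmethyl group or a plain methyl on the same nitrogen would separate the two.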